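From Chloro to Fluoro on a Shared Core

A few compounds are considered here, and "the series" means these few. Any claim that something is new, unique, unknown or untested is made for them only; others in the source may bear on it.

Of the compounds shown here, two sharing one core have been measured in a functional assay on HEL cells (Homo sapiens) for cytotoxicity; on this read-out higher numbers stand for weaker inhibition and lower numbers for stronger inhibition. Compound 1 `O=C1O/C(=C\Cn2cc(C(F)(F)F)c(=O)[nH]c2=O)C(OCc2ccccc2)=C1OCc1ccccc1`, which carries trifluoromethyl, gives 1000 nM. Compound 2 `O=C1O/C(=C\Cn2cc(Cl)c(=O)[nH]c2=O)C(OCc2ccccc2)=C1OCc1ccccc1`, which carries chloro at the same aromatic carbon, gives 3000 nM, the higher of the two numbers and therefore the weaker inhibition of the pair.

Compound 3 `O=C1O/C(=C\Cn2cc(F)c(=O)[nH]c2=O)C(OCc2ccccc2)=C1OCc1ccccc1` has not yet been measured in this assay. It differs from compound 2 by fluoro in place of chloro on an aromatic carbon.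

Among the compounds with values here, only one measured step bears on this change: a 3.0-fold higher number from compound 1 to compound 2 (0.48 log units; beyond the scatter). It shows that a swap at this carbon can move the number by a modest amount beyond the scatter, but it involves trifluoromethyl rather than fluoro and so gives only weak guidance on direction. A small step towards a lower number is therefore expected, with a rise not excluded. The expected change is a 1.5-fold lower number from compound 2 to compound 3 (0.18 log units; within the scatter), which would not clearly exceed the scatter. Compound 3 is estimated at 2000 nM, with an expected range of 600 nM to 6000 nM.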

Compound 3, half-maximal inhibitory concentration: 9000 nM
The estimate for compound 3 lay 4.5-fold (0.65 log units) below the measured number, and the stated range ends below it.
By their numbers in this assay, from the lowest: compound 1; then compound 2; then compound 3.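

In this assay, exchanging chloro for fluoro gave a 3.0-fold higher number from compound 2 to compound 3 (0.48 log units; beyond the scatter), so this aromatic carbon responds beyond the scatter even to a swap of one heavy atom for another, with no change in rings, hydrogen-bond donors, hydrogen-bond acceptors or net charge. The earlier step had involved only trifluoromethyl and chloro; the new compound extends the series to a 9.0-fold higher number from compound 1 to compound 3 (0.95 log units; beyond the scatter), which makes compound 3 the weakest inhibitor and compound 1 the strongest of the three, with chloro in compound 2 standing apart from both. Nothing available explains this order of trifluoromethyl, chloro and fluoro, so it stands as an observation on these three compounds alone.

What bromo, a methyl group, a nitrile or an amine at this carbon would give remains open, and so does whether any of these would fall within the range set by the three groups shown. As far as these compounds go, it is also open whether the same order would hold if the rest of the shared core were changed, since all three compounds differ only at this one carbon.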